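A few compounds are considered here, and "the series" means these few. Any claim that something is new, unique, unknown or untested is made for them only; others in the source may bear on it.

Measured compounds:
compound 1 `O=S(=O)(NCCCNCC1COc2ccccc2O1)c1cc(C(F)(F)F)cc(C(F)(F)F)c1` with 1500 nM
compound 2 `O=S(=O)(NCCCNCc1ccccc1)c1cc(C(F)(F)F)cc(C(F)(F)F)c1` with 4900 nM

For the measured compounds named here, of the two numbers in a functional assay on A2780 cells (Homo sapiens) for inhibition, read by MTT assay, with a stated time of 72 h (a lower number here means a stronger inhibitor of growth, a higher number a weaker inhibitor of growth), compound 2 holds the higher one; the only measured step, a 3.3-fold higher number from compound 1 to compound 2 (0.51 log units; beyond the scatter), separates it from compound 1. Compound 3 `O=S(=O)(NCCCNCc1ccc(Br)cc1)c1cc(C(F)(F)F)cc(C(F)(F)F)c1` differs from compound 2 by bromo in place of hydrogen on an aromatic carbon. Going by the values given here, no measured step concerns a substituent added to this ring; the step from compound 1 to compound 2 swapped the whole ring, so it offers no direct guide. The expectation is therefore a step of a 1.6-fold lower number from compound 2 to compound 3 (0.21 log units; within the scatter) that stays close to the scatter. Compound 3 is estimated at 3000 nM, within 1000 nM to 9000 nM.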

Compound 3, concentration for 50% growth inhibition: 2600 nM
For compound 3 the middle estimate is 1.2-fold (0.06 log units) above the measured one, within the range that was stated.
By their numbers in this assay, from the lowest: compounds 1, 3 and 2 (each within the scatter of the next, the first and the last beyond it).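

In this assay, for the compounds shown here, bromo is the first substituent measured on this aromatic carbon, and the step (a 1.9-fold lower number from compound 2 to compound 3 (0.28 log units; within the scatter)) stays within the usual scatter, so no clear effect of this one atom can be claimed. Replacing the ring of compound 1 with 4-bromophenyl (a 1.7-fold higher number from compound 1 to compound 3 (0.24 log units; within the scatter)) also stays within the scatter, unlike the change to plain phenyl (a 3.3-fold higher number from compound 1 to compound 2 (0.51 log units; beyond the scatter)). No measured evidence on the cause of these numbers is available.

As far as these compounds go, whether a methoxy group or an amine on this same carbon would give a step beyond the scatter remains open. So does the effect of a longer chain.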